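Series notes: bromo in place of nitro on compound 2

The compounds below may be only part of what the source reports. "The series", "measured", "known", "first", "only" and "open" are said of these compounds alone.

Measured so far in a functional assay on HCT-116 cells (Homo sapiens) for inhibition, read by sulforhodamine B assay, with a stated time of 72 h; a higher number here means a weaker inhibitor, a lower number a stronger inhibitor:
- compound 1 : `Cc1ccc(C2=Nn3c(nnc3C(C)c3ccc(CC(C)C)cc3)SC2)cc1`, 4000 nM
- compound 2 : `COc1ccc2cc(C(C)c3nnc4n3N=C(c3ccc([N+](=O)[O-])cc3)CS4)ccc2c1`, 15100 nM

Compound 2 stands at the higher of the two numbers in this assay, and compound 1 stands at the lower one; the gap between them lies beyond the usual scatter. The two share the core but differ in more than one place, so nothing is said here about the weight of any single change between them.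

Compound 3, `COc1ccc2cc(C(C)c3nnc4n3N=C(c3ccc(Br)cc3)CS4)ccc2c1`, is not yet measured. It differs from compound 2 in one place: bromo in place of nitro on an aromatic carbon. Among the compounds with values here, no pair of measured compounds shows this exchange on its own, so there is no measured step to lean on. The expectation is a step of modest size at most, with no firm direction, and most likely not beyond the scatter: the estimated step from compound 2 to compound 3 is a 1.4-fold lower number from compound 2 to compound 3 (0.14 log units; within the scatter). For compound 3 the estimate in this assay is 11000 nM, with a range from 4000 nM to 30000 nM.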

Compound 3, half-maximal inhibitory concentration: 11700 nM
Compound 3: middle estimate off by 1.1-fold (0.03 log units), on the low side; the measured number falls inside the stated range.
By their numbers in this assay, from the lowest: compound 1; then compounds 3 and 2 (each within the scatter of the next).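

In this assay, within the data shown here, the exchange of 4-nitrophenyl for 4-bromophenyl gives a 1.3-fold lower number from compound 2 to compound 3 (0.11 log units; within the scatter), the first measured step that isolates a single change. At this place, on an aromatic carbon para to a large group, replacing three heavy atoms and two hydrogen-bond acceptors with one heavy atom and no acceptors leaves compound 2 and compound 3 indistinguishable in this read-out, so within this pair the number does not depend on which of these two groups is present. No measured evidence bears on the reason for this outcome, and the step is recorded here only as an observation.

Among these compounds, whether an amine or a carboxylic acid at this same place would move the number beyond the scatter remains open, since nitro and bromo are the only two groups compared here on an otherwise unchanged structure. Among the compounds shown here, also open is whether the same exchange would give a similar step with the other substituents of compound 1 in place, as no measured pair tests it there.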